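Shortening a Side Chain on a Shared Core

The source may hold more compounds than are shown below. What is called first, only, known or untested is meant among the compounds shown, and "the series" means these compounds.

Of the compounds shown here, three that share one core have been measured in a functional assay, with a stated time of 90 min; on this read-out lower numbers stand for an effect already at smaller amounts and higher numbers for an effect only at larger amounts of compound. Compound 1 `CC(C)=NNc1nc(-c2cccc([N+](=O)[O-])c2)cs1` gives 1750000 nM. Compound 2 `CC/C(C)=N\Nc1nc(-c2cccc([N+](=O)[O-])c2)cs1` gives 1650000 nM, and compound 3 `CCCCC/C(CC)=N\Nc1nc(-c2cccc([N+](=O)[O-])c2)cs1` gives 1470000 nM. Compound 1 differs from compound 2 by hydrogen in place of methyl on a saturated chain carbon bound to a carbon with a double bond to nitrogen, and this change made a step of a 1.1-fold higher number from compound 2 to compound 1 (0.03 log units; within the scatter). The difference between the core of compound 2 and that of compound 3 is not broken down here; their two values lie close together.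

Compound 4 `CCCC/C(CC)=N\Nc1nc(-c2cccc([N+](=O)[O-])c2)cs1` has not yet been measured. It differs from compound 3 by hydrogen in place of methyl on a saturated chain carbon, four bonds along the chain from a carbon with a double bond to nitrogen. Among the compounds with values here, this is the same kind of change as the one from compound 2 to compound 1, though not the same: there the methyl sat on a saturated chain carbon bound to a carbon with a double bond to nitrogen, whereas here it sits on a saturated chain carbon four bonds along the chain from such a carbon. The earlier step was a 1.1-fold higher number from compound 2 to compound 1 (0.03 log units; within the scatter), and all three measured numbers sit within scatter of one another. The expected step is therefore a 1.1-fold higher number from compound 3 to compound 4 (0.04 log units; within the scatter). That expectation rests on compound 3 giving 1470000 nM. Compound 4 is estimated at 1600000 nM in this assay, between 900000 nM and 2800000 nM.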

Compound 4, half-maximal effective concentration: 1560000 nM
The estimate for compound 4 lay 1.0-fold (0.01 log units) above the measured number; the range from low to high includes it.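

In this assay, putting hydrogen in place of methyl on the longer chain gave a 1.1-fold higher number from compound 3 to compound 4 (0.03 log units; within the scatter), and set beside the earlier case, the two steps do not differ: the same change on two cores in this assay, a 1.1-fold higher number (0.03 log units; within the scatter) from compound 2 to compound 1 and a 1.1-fold higher number (0.03 log units; within the scatter) from compound 3 to compound 4, 1.0-fold (0.00 log units) apart, within the scatter of two such steps

So in these two cases the change carries from one core to the other in a limited sense: each time it leaves the number within the scatter of repeated measurements. This does not show a real effect of a fixed size, since steps this small cannot separate a slight effect from none, and two cases, with the methyl at a different place on the chain in each, make no general rule.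

The compounds shown carry only plain carbon chains on the carbon with a double bond to nitrogen, so it remains open whether an amine, a carboxylic acid or a much longer chain there would move the number beyond the scatter. Going by these compounds, it also remains open whether replacing the nitro group, which all four compounds carry, would matter more than any of these chain changes.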